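The source may hold more compounds than are shown below. What is called first, only, known or untested is meant among the compounds shown, and "the series" means these compounds.

Of the compounds shown here, two have been measured so far. Compound 1, `C[C@H](NC(=O)CN(c1nc(Cl)nc2[nH]cnc12)C1CC1)C(=O)OCc1ccccc1`, carries a chlorine-bearing purine core joined through a cyclopropyl-substituted nitrogen to an amide that ends in an alanine benzyl ester. In a functional assay on the whole organism (Tail, strain ICR) with Mus musculus as the target, in the tail flick test, with a stated time of 120 min, at a dose of 25 umol/kg by the oral route (on this read-out higher numbers stand for a stronger effect at the one dose given and lower numbers for a weaker effect), compound 1 gives 36.1%. Compound 2, `O=C(CN(c1ncnc2c1ncn2C1CCCCO1)C1CC1)N[C@@H](CCC(=O)OCc1ccccc1)C(=O)OCc1ccccc1`, differs in several places at once and gives 20.7% in this assay. Compound 1 therefore stands highest of the two numbers, and the gap to compound 2 lies beyond the usual scatter.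

Compound 3, `N=C(N)NCCC[C@H](NC(=O)CN(c1nc(Cl)nc2[nH]cnc12)C1CC1)C(=O)OCc1ccccc1`, has not yet been measured. It differs from compound 1 in exactly one place: a group of 6 heavy atoms (3 carbon, 3 nitrogen; no ring) in place of a hydrogen atom, on a saturated chain carbon, two bonds along the chain from an amide-type nitrogen and a carbonyl carbon. The cores and the benzyl ester of the two compounds are the same.

Among the measured compounds shown here, no pair of measured compounds differs in a single place, so there is no measured step to lean on. The expectation is a modest step from compound 1 to compound 3 of a number 6.1 percentage points lower from compound 1 to compound 3 (within the scatter), a change not clearly beyond the scatter. Compound 3 is accordingly estimated at 30% in this assay, with a range from 10% to 50%.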

Compound 3, a percentage reported as activity, at one dose (the size of the read-out at that dose, not a potency): 10.2%
Compound 3: the middle estimate sits 19.8 percentage points above what was measured; the measured number falls inside the stated range.
By their numbers in this assay, from the lowest: compound 3; then compound 2; then compound 1.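

This place on the saturated chain, two bonds along the chain from an amide-type nitrogen and a carbonyl carbon, responds clearly to what it carries: in this assay, a group of 6 heavy atoms (3 carbon, 3 nitrogen; no ring) in place of a hydrogen atom gives a number 25.9 percentage points lower from compound 1 to compound 3 (beyond the scatter). Among the compounds shown here, the core and the benzyl ester are the same in this pair, so this is the first single change that can be read on its own, and here the larger group goes with a weaker effect at the one dose given. No measurement available here gives a reason for this step.

One change at one place cannot show whether the loss belongs to the whole group or only to part of it, such as its chain or the nitrogen-rich end. A plain amine on a chain of the same length, a carboxylic acid at that end, or a simple methyl group at this place would help separate these possibilities, and the same change on another core would test whether the step carries over.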